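A few compounds are considered here, and "the series" means these few. Any claim that something is new, unique, unknown or untested is made for them only; others in the source may bear on it.

Measured in a functional assay on DLD-1 cells (Homo sapiens) for cytotoxicity, read by resazurin assay, with a stated time of 48 h; on this read-out higher numbers stand for an effect only at larger amounts of compound and lower numbers for an effect already at smaller amounts:
- compound 1 `COc1c(Br)cccc1C(=O)Nc1ccc(Sc2nc3ccccc3s2)cc1`: 40000 nM
- compound 2 `O=C(Nc1ccc(Sc2nc3ccccc3s2)cc1)c1cccc(Br)c1O`: 12000 nM

Among the measured compounds shown here, compound 2 holds the lower of the two numbers in this assay, and compound 1 is its only neighbour. For the measured compounds named here, the single measured step is a 3.3-fold lower number from compound 1 to compound 2 (0.52 log units; beyond the scatter), and it comes from hydrogen in place of methyl on an oxygen on an aromatic ring.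

Compound 3 `O=C(Nc1ccc(Sc2nc3ccccc3s2)cc1)c1cc(Br)cc(Br)c1O` has not yet been measured. It differs from compound 2 in one place: bromo in place of hydrogen on an aromatic carbon. In words, this is bromo in place of hydrogen on an aromatic carbon, para to a hydroxy group.

Going by the values given here, no measured step covers this change, so the direction rests on thin evidence. Among the compounds with values here, the one step available involves a different change and serves only as a rough scale for a single-place edit in this small set. A modest step towards a lower number in this assay is therefore expected, although a result within the scatter would not be surprising. The expected step is a 2.4-fold lower number from compound 2 to compound 3 (0.38 log units; beyond the scatter). For compound 3 the estimated value is 5000 nM, with an expected range from 1500 nM to 15000 nM.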

Compound 3, half-maximal effective concentration: 20000 nM
The estimate for compound 3 lay 4.0-fold (0.60 log units) below the measured number, and the stated range ends below it.
By their numbers in this assay, from the lowest: compounds 2, 3 and 1 (each within the scatter of the next, the first and the last beyond it).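

In this assay, bromo in place of hydrogen on the aromatic carbon para to a hydroxy group, which turns 3-bromo-2-hydroxyphenyl into 3,5-dibromo-2-hydroxyphenyl, gives a 1.7-fold higher number from compound 2 to compound 3 (0.22 log units; within the scatter) and so shows that this position accepts a second bromo without a change that can be told from the usual scatter. Among the compounds shown here, the exchange of groups on the carbonyl carbon likewise gives a 2.0-fold lower number from compound 1 to compound 3 (0.30 log units; within the scatter) and also stays within the scatter, which leaves a 3.3-fold lower number from compound 1 to compound 2 (0.52 log units; beyond the scatter) as the only step here that lies beyond it. Nothing available bears on why this position responds as it does.

The compounds shown leave open whether any other group at this position, such as an amine, a carboxylic acid or a longer chain, would move the number beyond the scatter. They also leave open how a bromo at this position behaves when a methyl sits on the oxygen of the hydroxy group, as it does in compound 1.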